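Half-life notes on a larger piperidine group

The source may report more compounds than this note shows. Statements on the series, on what has been measured and on what is new or still open speak of the compounds shown alone.

Within the data shown here, only two compounds have results so far in an ADME assay on microsomes from liver (Rattus norvegicus) for metabolic stability, read by LC-MS, using NADPH, at 37 degrees C; a lower number here means that the compound disappears faster, a higher number that the compound lasts longer. Compound 1 `Cc1ccccc1-c1nc(CN2CCC(C(=O)NCCCN3CCC(C)CC3)CC2)c(C)o1` gives > 0.5 h, which is a limit of the assay and not a number. Compound 1 therefore stands at the limit of > 0.5 h in this assay, at which 1 of the 2 values shown sits. Among the measured compounds shown here, compound 2 `Cc1oc(-c2ccc(F)cc2)nc1CN1CCC(C(=O)NCCCN2C[C@H](C)C[C@H](C)C2)CC1` gives 0.468 h, but no single-place step connects it with compound 1, and the series offers no measured step as a guide.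

Compound 3 `Cc1ccccc1-c1nc(CN2CCC(C(=O)NCCCN3CCCC(CC(C)C)C3)CC2)c(C)o1` differs from compound 1 in one place: a group of 10 heavy atoms (9 carbon, 1 nitrogen; one six-membered non-aromatic ring with 1 hetero atom) in place of a group of 7 heavy atoms (6 carbon, 1 nitrogen; one six-membered non-aromatic ring with 1 hetero atom), on a saturated chain carbon, three bonds along the chain from an amide-type nitrogen. The change lies on a saturated chain carbon, three bonds along the chain from an amide-type nitrogen. In this assay, the expected move is an at least 1.4-fold lower number from compound 1 to compound 3 (0.15 log units; that floor lies within the scatter), a modest decrease close to the usual scatter. For the measured compounds named here, the only numerical anchor is compound 2 at 0.468 h. For compound 3, the half-life is estimated at 0.35 h, with an expected range from 0.15 h to 0.7 h.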

Compound 3, half-life: 0.0383 h
Compound 3: the middle estimate sits 9.1-fold (0.96 log units) above what was measured; measured number outside the range, below it.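

This position, on a saturated chain carbon, three bonds along the chain from an amide-type nitrogen, is not indifferent to the group it carries: in this assay, the group of 10 heavy atoms in place of 4-methylpiperidin-1-yl gives an at least 13-fold lower number from compound 1 to compound 3 (1.11 log units; beyond the scatter). Among these compounds, this is the first measured step, and it shows that a change in this one place can by itself move the half-life by that much. Compound 1 holds only a limit, so the step is a floor and not a full size: the limit of > 0.5 h in this assay, at which 1 of the 3 values shown sits.

A single step cannot separate the size of the entering group from its shape. As far as these compounds go, how a morpholine or an unsubstituted piperidine at the same place would read in this assay stays open, as does whether the step carries over to the core of compound 2.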